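A few compounds are considered here, and "the series" means these few. Any claim that something is new, unique, unknown or untested is made for them only; others in the source may bear on it.

Measured so far in an assay on microsomes from intestine for inhibition of acyl-CoA:cholesterol acyltransferase (Oryctolagus cuniculus); on this read-out higher numbers stand for weaker inhibition and lower numbers for stronger inhibition:
compound 1, `CCCCCCOC(=O)NC(=O)Oc1c(C(C)C)cccc1C(C)C`, 53 nM
compound 2, `CCCCCCCCCCCCCOC(=O)NC(=O)Oc1c(C(C)C)cccc1C(C)C`, 9 nM

Compound 2 holds the lowest of the two numbers in this assay. For the measured compounds named here, its nearest neighbour is compound 1, and the only step in the set is the one between them: a 5.9-fold lower number from compound 1 to compound 2 (0.77 log units; beyond the scatter).

Compound 3, `CCCCCCCCCCCCCCOC(=O)NC(=O)Oc1c(C(C)C)cccc1C(C)C`, differs from compound 2 by methyl in place of hydrogen on a saturated chain carbon, ten or more bonds along the chain from an oxygen next to a carbonyl group. Going by the values given here, the single measured step bears on this change only loosely: it exchanged hydrogen for a heptyl and went with a modest lowering, whereas the present change adds a methyl alone at the far end of an already long chain. No step beyond the scatter is therefore expected for compound 3, with at most a slight lowering of the number as the direction to lean towards.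

For compound 3 the expected step is a 1.3-fold lower number from compound 2 to compound 3 (0.11 log units; within the scatter), and the estimate in this assay is 7 nM, in the range 3 nM to 18 nM.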

Compound 3, half-maximal inhibitory concentration: 10 nM
For compound 3 the middle estimate is 1.4-fold (0.15 log units) below the measured one; low and high end bracket the measured number.
By their numbers in this assay, from the lowest: compounds 2 and 3 (each within the scatter of the next); then compound 1.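

In this assay, methyl in place of hydrogen on a saturated chain carbon, ten or more bonds along the chain from an oxygen next to a carbonyl group, gives a step within the scatter (a 1.1-fold higher number from compound 2 to compound 3 (0.05 log units; within the scatter)), so this added carbon makes no readable difference at this place. Octyl in place of hydrogen, six bonds along the chain from that oxygen, gives a step beyond the scatter (a 5.3-fold lower number from compound 1 to compound 3 (0.72 log units; beyond the scatter)), so the stronger inhibition seen with a long chain persists with one more carbon. Nothing available explains either step.

Still open, going by these compounds, is whether a longer chain would keep the number or begin to raise it. Equally open, on these data alone, is how a carboxylic acid or an amine on the chain would read in this assay.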